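Amide nitrogen substituent swap in the hydroxy series

The compounds below may be only part of what the source reports. "The series", "measured", "known", "first", "only" and "open" are said of these compounds alone.

Measured so far:
- compound 1, `CC[C@@H](C)[C@H](NC(=O)c1ccc(C(CC)(CC)c2ccc(OCC(=O)C(C)(C)C)c(C)c2)n1CC)C(=O)OC`, 590 nM
- compound 2, `CCn1c(C(=O)NCCN)ccc1C(CC)(CC)c1ccc(OCC(=O)C(C)(C)C)c(C)c1`, 120 nM
- compound 3, `CC[C@@H](C)[C@H](NC(=O)c1ccc(C(CC)(CC)c2ccc(OCC(O)C(C)(C)C)c(C)c2)n1CC)C(=O)OC`, 26 nM

In an assay on HL-60 cells for agonist activity at vitamin D3 receptor (Homo sapiens), read by microscopy, with a stated time of 96 h (on this read-out higher numbers stand for an effect only at larger amounts of compound and lower numbers for an effect already at smaller amounts), compound 3 holds the lowest number of the three, with compound 2 nearest and compound 1 furthest, both steps beyond the scatter. Compound 4, `CCn1c(C(=O)N(C)c2ccccc2)ccc1C(CC)(CC)c1ccc(OCC(O)C(C)(C)C)c(C)c1`, keeps the hydroxy side chain of compound 3 and changes only the amide: methyl(phenyl)amino in place of (1-(methoxycarbonyl)-2-methylbutyl)amino on a carbonyl carbon.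

Among the compounds with values here, one measured step touches the same position: a 4.9-fold lower number from compound 1 to compound 2 (0.69 log units; beyond the scatter), where the substituent on the amide-type nitrogen was exchanged within the ketone series. Within the data shown here, that step was modest and only shows that this position tolerates exchange; the new group here is a tertiary amide without hydrogen-bond donor or acceptor, for which no analogue exists in the set. The large step of a 23-fold lower number from compound 1 to compound 3 (1.36 log units; beyond the scatter) concerns the side chain, which compound 4 shares with compound 3, and so sets the starting level rather than the direction.

Expectation: a step of about a 1.2-fold higher number from compound 3 to compound 4 (0.06 log units; within the scatter) in this assay, close to no change beyond the scatter, with a wide range. Compound 4 is therefore estimated at 30 nM, between 8 nM and 120 nM.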

Compound 4, half-maximal effective concentration: 6400 nM
The estimate for compound 4 lay 210-fold (2.33 log units) below the measured number, and the stated range ends below it.
By their numbers in this assay, from the lowest: compound 3; then compound 2; then compound 1; then compound 4.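

In this assay, methyl(phenyl)amino in place of (1-(methoxycarbonyl)-2-methylbutyl)amino gives a 250-fold higher number from compound 3 to compound 4 (2.39 log units; beyond the scatter), so the exchange seen in a 4.9-fold lower number from compound 1 to compound 2 (0.69 log units; beyond the scatter) does not mean that every group is accepted on this carbonyl carbon. The change removes the amide hydrogen and the methoxycarbonyl group and brings in a six-membered aromatic ring all at once, and the compounds shown cannot separate these parts. No available evidence bears on the reason for this result.

Open, from the compounds shown here alone, is whether phenylamino, which keeps the amide hydrogen, or methylamino on this carbonyl carbon would stay close to compound 3 or fall close to compound 4. Also open, going by these compounds, is whether 2-aminoethyl on the amide nitrogen would have the same effect in the hydroxy series as in the ketone series.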